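This account rests on a few compounds, and the source may have more. Where it says the series, first, only, none or still open, it means among the compounds named here.

Working notes on the series. In an assay on isolated protein for displacement of a labelled ligand from Bile acid receptor (Homo sapiens), read by scintillation proximity assay and radioligand binding (on this read-out higher numbers stand for weaker inhibition and lower numbers for stronger inhibition), compound 1 `COc1ccccc1-c1noc(C(C)C)c1COc1ccc(/C=C/c2cccc(C(=O)O)c2)c(Cl)c1` gives 250 nM. Compound 2 `COc1ccc(Cl)c(-c2noc(C(C)C)c2COc2ccc(-c3ccc4c(C(=O)O)cn(C)c4c3)c(C)c2)n1` gives 310 nM in this assay, the highest of the two numbers, while the gap to compound 1 lies within the scatter. Compound 3 `Cc1cc(OCc2c(-c3c(Cl)cn(C)c(=O)c3Cl)noc2C(C)C)ccc1-c1ccc2c(C(=O)O)cn(C)c2c1` is not yet measured; it differs from compound 2 by a group of 10 heavy atoms (6 carbon, 1 nitrogen, 1 oxygen, 2 chlorine; one six-membered aromatic ring with 1 hetero atom) in place of a group of 9 heavy atoms (6 carbon, 1 nitrogen, 1 oxygen, 1 chlorine; one six-membered aromatic ring with 1 hetero atom), on an aromatic carbon. Within the data shown here, no measured pair isolates such a change, so only a modest step is expected from compound 2, with no clear direction beyond the scatter: the expected step is a 1.3-fold higher number from compound 2 to compound 3 (0.11 log units; within the scatter). Compound 3 is therefore estimated at 400 nM, with a range of 130 nM to 1200 nM.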

Compound 3, half-maximal inhibitory concentration: 2750 nM
For compound 3 the middle estimate is 6.9-fold (0.84 log units) below the measured one; the measured number lies above the stated range.
By their numbers in this assay, from the lowest: compounds 1 and 2 (each within the scatter of the next); then compound 3.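

In this assay this position, on an aromatic carbon next to the ring nitrogen of the five-membered ring, proves sensitive: replacing 3-chloro-6-methoxypyridin-2-yl with a group holding a second chlorine and a double bond outside aromatic rings gives an 8.9-fold higher number from compound 2 to compound 3 (0.95 log units; beyond the scatter) in the number. The hydrogen-bond donor and acceptor counts stay the same across this change. Nothing measured here accounts for the step.

The compounds shown do not separate the second chlorine from the other differences between the two groups. Also open, as far as these compounds go, is how a nitrile or an amine in place of that chlorine would read.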